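The source may report more compounds than this note shows. Statements on the series, on what has been measured and on what is new or still open speak of the compounds shown alone.

Of the compounds shown here, three that share one core have been measured in a functional assay on HepG2 cells (Homo sapiens) for cytotoxicity, read by MTT assay, with a stated time of 48 h; a lower number here means a stronger inhibitor, a higher number a weaker inhibitor. Compound 1 `Cc1ccccc1-c1nnc(SCCn2c([N+](=O)[O-])cnc2C)o1` gives 5100 nM, compound 2 `Cc1ccc(-c2nnc(SCCn3c([N+](=O)[O-])cnc3C)o2)cc1` gives 2200 nM, and compound 3 `Cc1ncc([N+](=O)[O-])n1CCSc1nnc(-c2ccc(Cl)cc2)o1` gives 7800 nM. Compound 3 sits at the weak end of this small set, but not alone. The data show a 1.5-fold higher number from compound 1 to compound 3 (0.18 log units; within the scatter), and also a 3.5-fold higher number from compound 2 to compound 3 (0.55 log units; beyond the scatter).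

Compound 4 `Cc1ccc(-c2nnc(SCCn3c([N+](=O)[O-])cnc3C)o2)c(O)c1` carries 2-hydroxy-4-methylphenyl in place of 4-chlorophenyl on an aromatic carbon.

The most useful guide is compound 2, which carries 4-methylphenyl and so shares the methyl of the entering group. Its measured step, a 3.5-fold higher number from compound 2 to compound 3 (0.55 log units; beyond the scatter), suggests that leaving chloro behind could lower the number. The step of a 2.3-fold lower number from compound 1 to compound 2 (0.37 log units; beyond the scatter) is of similar modest size and shows that these small changes on the aromatic group can move the number. Going by the values given here, no measured compound carries a hydroxy group, so that part of the change remains an open question and widens the range. A modest step towards a lower number is therefore expected in this assay, smaller than the full distance to compound 2.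

The expected change is a 2.2-fold lower number from compound 3 to compound 4 (0.35 log units; beyond the scatter). For compound 4 the estimated value is 3500 nM, with an expected range from 1200 nM to 10000 nM.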

Compound 4, half-maximal inhibitory concentration: 16600 nM
Estimate against measurement, compound 4: 4.7-fold (0.68 log units) below; the whole stated range lies below it.
By their numbers in this assay, from the lowest: compound 2; then compounds 1 and 3 (each within the scatter of the next); then compound 4.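

In this assay, the clearest reading comes from the pair that differs only by hydroxy in place of hydrogen on the aromatic ring: a 7.5-fold higher number from compound 2 to compound 4 (0.88 log units; beyond the scatter), the largest step among these compounds. The other two comparisons point the same way, with a 3.3-fold higher number from compound 1 to compound 4 (0.51 log units; beyond the scatter) and a 2.1-fold higher number from compound 3 to compound 4 (0.33 log units; beyond the scatter), although each also changes other parts of the aromatic group. Compound 4 is therefore the weakest of the four, so this added hydroxy goes with a weaker result here, whereas the earlier swaps of methyl and chloro had produced smaller shifts; nothing available explains why the number rises.

What remains open is whether this rise belongs to the hydroxy group itself or to its particular place in 2-hydroxy-4-methylphenyl, since only one hydroxy-bearing compound is shown. A methoxy group or an amine at that same place, or a hydroxy group on a phenyl ring without the methyl, would help separate these possibilities and show whether other groups there follow the same direction.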